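Fluoro in place of (vinylcarbonyl)oxy: persistence expected

The source may report more compounds than this note shows. Statements on the series, on what has been measured and on what is new or still open speak of the compounds shown alone.

Measured so far in an ADME assay for pharmacokinetics, read by HPLC, in phosphate buffer, with a stated time of 72 h, at pH 7.4, tested at 250 uM; a higher number here means that the compound lasts longer, a lower number that the compound disappears faster:
Compound 1, `C=CC(=O)Oc1cc(C(F)(F)F)cc(C(F)(F)F)c1`, gives < 0.017 h, which is a limit of the assay and not a number.
Compound 2, `C=Cc1cc(C(F)(F)F)cc(C(F)(F)F)c1`, gives > 50 h, also a limit.
Compound 3, `O=C(CBr)c1cc(C(F)(F)F)cc(C(F)(F)F)c1`, gives < 0.017 h, a limit as well.

Compound 1 thus stands at the limit of < 0.017 h in this assay, at which 2 of the 3 values shown sit, so only a limit is known for it, and none of the three measured compounds yields a plain number. The unmeasured compound 4, `Fc1cc(C(F)(F)F)cc(C(F)(F)F)c1`, differs from compound 1 in a single place: fluoro in place of (vinylcarbonyl)oxy on an aromatic carbon. The measured step that bears most on this change is an at least 2900-fold higher number from compound 1 to compound 2 (3.46 log units; beyond the scatter), where the same (vinylcarbonyl)oxy group leaves the aromatic carbon and a small group without oxygen, vinyl, takes its place. The step that the two limits leave unreadable from compound 1 to compound 3 cannot be sized, while an at least 2900-fold lower number from compound 2 to compound 3 (3.46 log units; beyond the scatter) shows the number falling again once a (bromomethyl)carbonyl group replaces vinyl. Fluoro, like vinyl, brings no carbonyl and no oxygen, and the expectation is that removing the (vinylcarbonyl)oxy group matters more than what small group enters. In this assay a large rise is therefore expected: an at least 17000-fold higher number from compound 1 to compound 4 (4.24 log units; beyond the scatter). For compound 4 the estimated half-life is 300 h, within a range from 50 h to 2000 h, most likely reported once more only as a limit.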

Compound 4, half-life: > 50 h
Compound 4: a limit, no number (the forecaster's own chance of this, stated with the estimate: 85%); the middle value lies beyond the limit too.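

Among the compounds shown here, at this aromatic carbon of the shared core, fluoro in place of (vinylcarbonyl)oxy gives an at least 2900-fold higher number from compound 1 to compound 4 (3.46 log units; beyond the scatter) in this assay, so vinyl is no longer the only small group known to give a long-lasting compound here. Fluoro in place of (bromomethyl)carbonyl gives an at least 2900-fold higher number from compound 3 to compound 4 (3.46 log units; beyond the scatter), which shows the same kind of rise from the other short-lived compound, and with the entering group being a single fluorine atom with no double bond. Compound 4 gives a limit of the assay and not a number, and it shares that limit with one other compound: the limit of > 50 h in this assay, at which 2 of the 4 values shown sit.

The step between compound 2 and compound 4 cannot be read, so the compounds shown do not tell whether fluoro or vinyl gives the longer half-life. Also open, as far as these compounds go, is where an amine, a methoxy group or an amide on the same aromatic carbon would fall, and whether any of them would give a plain number between the two limits.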